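Methoxymethyl to ethoxymethyl: compound 2 to compound 3

The compounds below may be only part of what the source reports. "The series", "measured", "known", "first", "only" and "open" are said of these compounds alone.

In a functional assay on MES-SA cells (Homo sapiens) for inhibition, with a stated time of 72 h (on this read-out higher numbers stand for weaker inhibition and lower numbers for stronger inhibition), compound 1 `CC1CCN(Cc2cc(Cl)c3cccnc3c2O)CC1` gives 2700 nM; 2690 nM (2 entries), two entries that agree closely. On the same read-out compound 2 `COCc1cc(CN2CCC(C)CC2)c(O)c2ncccc12` gives 6170 nM, the higher of the two numbers shown and so the weaker inhibition of this pair. A further entry for compound 2 carries no single number.

Compound 3 `CCOCc1cc(CN2CCC(C)CC2)c(O)c2ncccc12` differs from compound 2 in one place: methyl in place of hydrogen on a saturated chain carbon bound to an oxygen on a saturated carbon. This is methyl in place of hydrogen on a saturated chain carbon bound to an oxygen on a saturated carbon, turning methoxymethyl into ethoxymethyl.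

For the measured compounds named here, no measured pair differs in one place only, and the effect of such a change in this assay has not been seen. The expectation therefore rests on compound 2 at 6170 nM, with no direction favoured for a single added methyl. The estimated change, a 1.1-fold lower number from compound 2 to compound 3 (0.05 log units; within the scatter), is expected to stay within the usual scatter. Compound 3 is expected at 5500 nM, with an estimated range of 2500 nM to 12000 nM.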

Compound 3, half-maximal inhibitory concentration: 4070 nM
For compound 3 the middle estimate is 1.4-fold (0.13 log units) above the measured one, and the stated range covers the measured number.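

For the compounds shown here, this is the first step that changes one place only, and it gives a first reading of that place in this assay: a 1.5-fold lower number from compound 2 to compound 3 (0.18 log units; within the scatter). On this read-out, methoxymethyl and ethoxymethyl cannot be told apart, so methyl in place of hydrogen on a saturated chain carbon bound to an oxygen on a saturated carbon produces no change that can be read. Repeat entries in this assay can agree much more closely than the usual scatter, but compound 2 has only one numerical value and compound 3 has one entry, so this pair lacks that check: the several entries of compound 1 in this assay, 2700 nM; 2690 nM (2 entries).

A single step on one chain does not show how far this flat reading extends, and a longer chain such as propoxymethyl, or a chain ending in an amine or a carboxylic acid, would test it further. As far as these compounds go, compound 2 and compound 3 share the rest of their structure, so it remains open whether the same methyl step would read alike on a different background.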